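Methyl in Place of Methoxy: an Expected Cytotoxicity Value

The compounds below may be only part of what the source reports. "The series", "measured", "known", "first", "only" and "open" are said of these compounds alone.

In an ADME assay on cells (Mus musculus, strain Balb/c) for cytotoxicity, read by MTT assay, with a stated time of 48 h (on this read-out lower numbers stand for higher toxicity in this test and higher numbers for lower toxicity in this test), compound 2 `COc1ccc(C(/C=C/c2ccc(Br)cc2)=N/O)cc1` gives 737000 nM, the second highest of three numbers. Compound 1 `COc1ccc(C(/C=C/c2ccc(Cl)cc2)=N/O)cc1` gives 291000 nM and compound 3 `COc1ccc(/C=C/C(=N\O)c2ccc(OC)cc2)cc1` gives 2170000 nM in this assay. The measured steps, a 2.5-fold higher number from compound 1 to compound 2 (0.40 log units; beyond the scatter), a 7.5-fold higher number from compound 1 to compound 3 (0.87 log units; beyond the scatter) and a 2.9-fold higher number from compound 2 to compound 3 (0.47 log units; beyond the scatter), all swap a single group on the other ring and are modest. Compound 4 `Cc1ccc(C(/C=C/c2ccc(Br)cc2)=N/O)cc1` differs from compound 2 by methyl in place of methoxy on an aromatic carbon. Within the data shown here, no measured step concerns this group; the three steps show only that single-group swaps moved the read-out modestly. Compound 4 is therefore expected to show a 1.5-fold lower number from compound 2 to compound 4 (0.17 log units; within the scatter), a step toward a lower number that may stay within the scatter. The estimate for compound 4 is 500000 nM, with a range from 150000 nM to 2000000 nM.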

Compound 4, half-maximal cytotoxic concentration: 34200 nM
Beside the measured number, compound 4's estimate is 15-fold (1.16 log units) above it; the whole stated range lies above it.
By their numbers in this assay, from the lowest: compound 4; then compound 1; then compound 2; then compound 3.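

Among these compounds, the position on the aromatic carbon para to a large group proves far more responsive than the earlier compounds could show: methyl in place of methoxy gives a 22-fold lower number from compound 2 to compound 4 (1.33 log units; beyond the scatter), a large step where every step on the other ring was modest. Removing this methoxy therefore moves the read-out toward higher toxicity in this test. Nothing available explains the size of this step.

As far as these compounds go, whether a hydroxy group or an ethyl chain at this position would behave like methyl remains open. So does whether the step would recur with chloro in place of bromo on the other ring.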